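This account rests on a few compounds, and the source may have more. Where it says the series, first, only, none or still open, it means among the compounds named here.

Compound 2 `c1cncc(N2CCN(Cc3nc4ccccc4[nH]3)CC2)c1` gives 376 nM in an assay on isolated protein for binding affinity to D(4) dopamine receptor (Homo sapiens); a higher number here means a weaker inhibitor, a lower number a stronger inhibitor. Compound 1 `Clc1ccccc1N1CCN(Cc2nc3ccc[nH]c-3n2)CC1` gives 719 nM in this assay, and the two numbers lie within the scatter of each other, so neither compound can be set apart from the other. Compound 3 `c1ccc2[nH]c(CN3CCN(c4ccncc4)CC3)nc2c1` carries pyridin-4-yl in place of pyridin-3-yl on an amine nitrogen in a ring. For the measured compounds named here, no measured pair isolates this change, so its direction is uncertain; a modest weakening of binding, at or just beyond the scatter, is expected. For compound 3 an inhibition constant of 800 nM is estimated, between 250 nM and 2500 nM. This expected shift amounts to a 2.1-fold higher number from compound 2 to compound 3 (0.33 log units; beyond the scatter).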

Compound 3, inhibition constant: > 10000 nM
Compound 3: no number, only a limit; the forecaster's own chance of this, stated with the estimate: 5%; at least 12-fold (1.09 log units) between middle value and limit.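

On the amine nitrogen in a ring, pyridin-4-yl in place of pyridin-3-yl gives an at least 26-fold higher number from compound 2 to compound 3 (1.42 log units; beyond the scatter) in this assay. The two groups have the same atoms and the same counts of donors and acceptors, so at this position the way the pyridine ring is joined is enough on its own to cost much of the binding seen with compound 2. The reading for compound 3 is a limit and not a number: the limit of > 10000 nM in this assay, at which 1 of the 3 values shown sits.

Going by these compounds, the full size of the step therefore stays unknown. On these data alone, whether pyridin-2-yl or an unsubstituted phenyl on the same nitrogen would hold binding also stays open.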